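Working notes: from compound 1 to compound 3

A few compounds are considered here, and "the series" means these few. Any claim that something is new, unique, unknown or untested is made for them only; others in the source may bear on it.

- compound 1 `C[C@@H]1C[C@H]1C(=O)N1CCN(c2nc(-c3cnn(C)c3)ncc2C#N)C[C@H]1C` reads 1.9 
- compound 2 `Cn1cc(-c2ncc(C#N)c(N3C[C@@H]4C[C@H]3CN4C(=O)C3CC3)n2)cn1` reads 1.1 

Among the measured compounds shown here, both values come from a physicochemical assay for lipophilicity, read by HPLC (a lower number here means a more polar compound, a higher number a more lipophilic compound), and they are the only numbers so far. Compound 1 stands highest of the two, and the gap down to compound 2 lies beyond the scatter. For the measured compounds named here, these two compounds differ in more than one place, so the gap does not isolate any single change, and no measured pair serves as a precedent for the next step.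

Compound 3 `C[C@@H]1CN(c2nc(-c3cnn(C)c3)ncc2C#N)CCN1C(=O)C1(C)CC1` is still to be measured. It has the same atoms as compound 1, joined differently: 1-methylcyclopropyl in place of 2-methylcyclopropyl on a carbonyl carbon and the two groups match in every count shown. Going by the values given here, with no measured step to draw on, no direction is favoured, and a shift beyond the scatter in this assay is not expected. The expected change is no change at the digits printed from compound 1 to compound 3 (within the scatter) and this estimate rests on compound 1 alone, at 1.9 as the anchor. Compound 3 is expected at 1.9 with an estimated range from 1.6 to 2.2 in the same measurement.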

Compound 3, distribution coefficient: 1.7
Beside the measured number, compound 3's estimate is 0.20 log units above it; the range from low to high includes it.
By their numbers in this assay, from the lowest: compound 2; then compounds 3 and 1 (each within the scatter of the next).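

Putting 1-methylcyclopropyl in place of 2-methylcyclopropyl on a carbonyl carbon, with the rest of the molecule unchanged, gives a number 0.20 log units lower from compound 1 to compound 3 (within the scatter) in this assay, so at this place the read-out does not separate the two groups. Among the compounds shown here, this is the first comparison that differs in one place only, and it shows that moving the methyl group around the three-membered ring, with the 2 defined stereocentres of the leaving group gone from this substituent, comes with no step beyond the scatter. No measurement bearing on why the two groups read alike is available.

The comparisons of compound 2 with compound 1 and compound 3 cannot be read as steps, since compound 2 differs from each in more than one place, so its separate contributions remain unassigned. Also open, on these data alone, is whether a group of different atoms on the same carbonyl carbon, such as an amine, a carboxylic acid or a longer chain, would shift this assay beyond the scatter, as this isomeric pair speaks only for two groups with the same atoms.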